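Trifluoromethyl for Fluoro on an Aryl Urea Nitrile

The compounds below may be only part of what the source reports. "The series", "measured", "known", "first", "only" and "open" are said of these compounds alone.

Measured compounds:
- compound 1, `CCCCNC(=O)N1CC1C#N`, gives 12000 nM in a functional assay on L1210 cells (Mus musculus) for inhibition, read by MTT assay; a higher number here means a weaker inhibitor, a lower number a stronger inhibitor
- compound 2, `N#CC1CN1C(=O)Nc1ccc(F)cc1`, gives 5900 nM
- compound 3, `N#CC1CN1C(=O)Nc1ccc(Cl)cc1Cl`, gives 33000 nM

Among the three measured compounds, compound 2 gives the lowest number in this assay. Compound 1 stands above it by a gap beyond the scatter, and compound 3 further still. Compound 2 and compound 3 share the aryl urea nitrile core, but they differ in more than one place, so only their two values can be compared, not a single change.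

Compound 4, `N#CC1CN1C(=O)Nc1ccc(C(F)(F)F)cc1`, differs from compound 2 in one place: trifluoromethyl in place of fluoro on an aromatic carbon. Within the data shown here, no measured pair in this set isolates such a change, so neither the size nor the direction of the step can be read from the data, and the expectation rests on the spread of the three measured values alone. The expected step of a 1.4-fold higher number from compound 2 to compound 4 (0.13 log units; within the scatter) is estimated to be small, leaning toward a higher number but not clearly beyond the scatter. Compound 4 is therefore expected to give about 8000 nM in this assay, with a range from 3000 nM to 25000 nM.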

Compound 4, half-maximal inhibitory concentration: 7100 nM
Compound 4: middle estimate off by 1.1-fold (0.05 log units), on the high side, within the range that was stated.
By their numbers in this assay, from the lowest: compounds 2, 4 and 1 (each within the scatter of the next, the first and the last beyond it); then compound 3.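

Trifluoromethyl in place of fluoro on this aromatic carbon gives a 1.2-fold higher number from compound 2 to compound 4 (0.08 log units; within the scatter) in this assay. Among these compounds, this is the first step in the set that isolates a single change, and it shows that, at this position, a group of 4 heavy atoms can replace one of 1 heavy atom with no difference beyond the scatter. Nothing available explains why the two compounds read alike.

The compounds shown leave open whether the same holds for an amine, a carboxylic acid or a longer chain such as butyl on this aromatic carbon. They also leave open how compound 2 or compound 4 compares with the same core carrying plain hydrogen at this position, which would show whether a substituent here matters at all.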